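A few compounds are considered here, and "the series" means these few. Any claim that something is new, unique, unknown or untested is made for them only; others in the source may bear on it.

Compound 3 `O=C1O[C@H]([C@@H](O)Cn2cc(CNS(=O)(=O)c3ccc(Cl)cc3)nn2)C(OCc2ccccc2)=C1OCc1ccccc1` stands level with compound 2 `CC(C)(C)c1cn(C[C@H](O)[C@H]2OC(=O)C(OCc3ccccc3)=C2OCc2ccccc2)nn1` in a functional assay on SW-620 cells (Homo sapiens) for antiproliferative activity, read by MTT assay, with a stated time of 72 h (a higher number here means a weaker inhibitor, a lower number a stronger inhibitor), within the usual scatter: compound 3 gives (18000 nM) and compound 2 gives (35800 nM), which is (a 2.0-fold lower number from compound 2 to compound 3 (0.30 log units; within the scatter)). Compound 1 `COc1ccccc1-c1cn(C[C@H](O)[C@H]2OC(=O)C(OCc3ccccc3)=C2OCc2ccccc2)nn1` returns only a limit of the assay (> 100000 nM). Both other compounds stand clear of that limit (an at least 2.7-fold lower number from compound 1 to compound 2 (0.44 log units; beyond the scatter)) and (an at least 5.5-fold lower number from compound 1 to compound 3 (0.74 log units; beyond the scatter)).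

The next change leads to compound 4 `O=C1O[C@H]([C@@H](O)Cn2cc(CCCCl)nn2)C(OCc2ccccc2)=C1OCc1ccccc1`, where 2-chloroethyl takes the place of ((4-chlorophenyl)sulfonyl)amino on a saturated chain carbon bound to an aromatic carbon (2-chloroethyl in place of ((4-chlorophenyl)sulfonyl)amino on a saturated chain carbon bound to an aromatic carbon). The aromatic ring of compound 3 is lost, but that loss need not cost much: compound 2, with a tert-butyl group and no such ring at this point, gives (35800 nM). The large steps all start from compound 1 and its 2-methoxyphenyl group, which compound 4 does not carry. No step beyond the scatter is therefore expected in this assay, and the estimated step is (a 1.4-fold higher number from compound 3 to compound 4 (0.14 log units; within the scatter)). For compound 4 the expected value is 25000 nM in a range from 9000 nM to 70000 nM by this estimate.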

Compound 4, half-maximal inhibitory concentration: 68500 nM
Estimate against measurement, compound 4: 2.7-fold (0.44 log units) below; measured number inside the range.
By their numbers in this assay, from the lowest: compounds 3, 2 and 4 (each within the scatter of the next, the first and the last beyond it). At a limit, above all of these: compound 1.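

Swapping ((4-chlorophenyl)sulfonyl)amino for 2-chloroethyl on the saturated chain carbon gives a 3.8-fold higher number from compound 3 to compound 4 (0.58 log units; beyond the scatter), the first step beyond the scatter in this assay that does not start from compound 1, so this change can be read. Compound 2 also has no aromatic ring at this point, and 3-chloropropyl in place of tert-butyl gives a 1.9-fold higher number from compound 2 to compound 4 (0.28 log units; within the scatter), so compound 2 and compound 4 cannot be told apart. The last step, an at least 1.4-fold lower number from compound 1 to compound 4 (0.16 log units; that floor lies within the scatter), cannot be read, since the value of compound 1 is a limit of the assay: the limit of > 100000 nM in this assay, at which 1 of the 4 values shown sits.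

On these data alone, the aromatic ring, the sulfonyl group and the amino hydrogen all leave in one change, so it stays open which of them matters. As far as these compounds go, how an amine or a carboxylic acid on that chain would read in this assay is also open.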